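The source may report more compounds than this note shows. Statements on the series, on what has been measured and on what is new or still open speak of the compounds shown alone.

In a functional assay on HL-60 cells (Homo sapiens) for antiproliferative activity, read by MTT assay, with a stated time of 48 h (a higher number here means a weaker inhibitor, a lower number a stronger inhibitor), three compounds sharing one core have been measured. Compound 1 (`CCN(CC)C/C1=C/C[C@](C)(CCC=C(C)C)/C=C/[C@@H](OC(=O)C=C(C)C)[C@](C)(O)/C=C/C1=O`) gives 140 nM, compound 2 (`CC(C)=CCC[C@]1(C)/C=C/[C@@H](OC(=O)C=C(C)C)[C@](C)(O)/C=C/C(=O)/C(CN(C(C)C)C(C)C)=C\C1`) gives 740 nM, and compound 3 (`COCOC/C1=C/C[C@](C)(CCC=C(C)C)/C=C/[C@@H](OC(=O)C=C(C)C)[C@](C)(O)/C=C/C1=O`) gives 2840 nM, the highest number of the three and thus the weakest inhibitor among them. Compound 4 (`CO/N=C/C1=C/C[C@](C)(CCC=C(C)C)/C=C/[C@@H](OC(=O)C=C(C)C)[C@](C)(O)/C=C/C1=O`) keeps the shared core but loses the (methoxymethoxy)methyl of compound 3 on a double-bonded ring carbon: a group of 4 heavy atoms (2 carbon, 1 nitrogen, 1 oxygen; no ring) in place of a group of 5 heavy atoms (3 carbon, 2 oxygen; no ring), on a double-bonded ring carbon.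

Two measured steps end at compound 3. Methoxymethoxy in place of diethylamino gave a 20-fold higher number from compound 1 to compound 3 (1.31 log units; beyond the scatter), a large step, and methoxymethoxy in place of diisopropylamino gave a 3.8-fold higher number from compound 2 to compound 3 (0.58 log units; beyond the scatter), a modest one. Both steps remove an amino group, and neither compound 3 nor compound 4 carries one. Among the compounds with values here, no measured step exchanges two groups free of amino nitrogen, so this expectation is only loosely supported. No step beyond the scatter is expected in this assay, and the estimated step is a 1.4-fold lower number from compound 3 to compound 4 (0.15 log units; within the scatter). Compound 4 is expected at about 2000 nM, with an estimated range from 600 nM to 6000 nM.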

Compound 4, half-maximal inhibitory concentration: 4760 nM
For compound 4 the middle estimate is 2.4-fold (0.38 log units) below the measured one, within the range that was stated.
By their numbers in this assay, from the lowest: compound 1; then compound 2; then compounds 3 and 4 (each within the scatter of the next).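

In this assay, within the data shown here, the exchange of (methoxymethoxy)methyl for the new group of compound 4 is the first step at this double-bonded ring carbon between two groups free of amino nitrogen, and it stays within the scatter, a 1.7-fold higher number from compound 3 to compound 4 (0.22 log units; within the scatter). The new group does carry a nitrogen, yet compound 4 lies with compound 3 rather than with the two amines, a 6.4-fold higher number from compound 2 to compound 4 (0.81 log units; beyond the scatter) and a 34-fold higher number from compound 1 to compound 4 (1.53 log units; beyond the scatter), so among these compounds a nitrogen atom alone does not go with the lower numbers of the diethylamino and diisopropylamino compounds. Nothing available accounts for these differences.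

The compounds shown leave open how a smaller amine such as dimethylamino, or a ring amine such as pyrrolidine, would compare at this position. They also leave open where a carboxylic acid on the same carbon would fall.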